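Cytotoxicity notes: from compound 3 to compound 4

A few compounds are considered here, and "the series" means these few. Any claim that something is new, unique, unknown or untested is made for them only; others in the source may bear on it.

In an ADME assay on BJ cells (Homo sapiens) for cytotoxicity, with a stated time of 72 h (a higher number here means that more compound is needed for the effect, a lower number that less compound is needed), compound 1 `C=C[C@@](C)(/C=C/c1ccc(O)cc1)CCC1OC1(C)C` sits at a limit of the assay, > 36600 nM. Compound 2 `C=C[C@@](C)(/C=C/c1ccc(O)cc1)CC/C=C/C(=O)OCC` also sits at a limit, > 36600 nM. Among the measured compounds shown here, the only step between measured compounds that differ in one place, a step that the two limits leave unreadable from compound 1 to compound 2, is therefore unreadable. Compound 3 `C=C[C@@](C)(/C=C/c1ccc(O)c(C=O)c1)CCC=C(C)C` likewise sits at a limit, > 36600 nM. All three measured values share (the limit of > 36600 nM in this assay, at which 3 of the 3 values shown sit), so compound 3 cannot be separated from the others. Compound 4 `C=C[C@@](C)(/C=C/c1ccc(O)c(/C=C/c2ccc(Cl)cc2)c1)CCC=C(C)C` differs from compound 3 by 2-(4-chlorophenyl)ethenyl in place of formyl on an aromatic carbon. For the measured compounds named here, no measured step covers a change of this kind, and the one computed step has no readable size, so the expectation rests only on where compound 3 stands. The expected step is an at least 1.2-fold lower number from compound 3 to compound 4 (0.08 log units; that floor lies within the scatter), nothing beyond the scatter. Compound 4 is expected to give 30000 nM, in the range 8000 nM to 120000 nM.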

Compound 4, half-maximal effective concentration: > 36600 nM
Compound 4: only a limit was reported; the forecaster's own chance of this, stated with the estimate: 60%; at least 1.2-fold (0.08 log units) between middle value and limit.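

No step can be read from compound 3 to compound 4, as both sit at a limit: the limit of > 36600 nM in this assay, at which 4 of the 4 values shown sit.

The compounds shown leave open whether any change to the shared core moves the read-out in this assay.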